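Chain-end variants on a shared core: compounds 2 and 3

A few compounds are considered here, and "the series" means these few. Any claim that something is new, unique, unknown or untested is made for them only; others in the source may bear on it.

Two members of the series have numbers in an assay on isolated protein (urine) for inhibition of Myeloperoxidase (Homo sapiens), with a stated time of 5 min; a lower number here means a stronger inhibitor, a higher number a weaker inhibitor. Compound 1 `N#CCCCc1c[nH]c2ccc(F)cc12` gives 63 nM, and compound 2 `NC(=O)CCc1c[nH]c2ccc(F)cc12` gives 132 nM. Among the compounds with values here, the only step between measured compounds is a 2.1-fold higher number from compound 1 to compound 2 (0.32 log units; beyond the scatter), a modest move but beyond the scatter. Within the data shown here, compound 2 therefore stands at the higher of the two numbers, with compound 1 as its only and nearest neighbour.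

Compound 3 `ONCCCc1c[nH]c2ccc(F)cc12` is the next variant of compound 2: (hydroxyamino)methyl in place of carbamoyl on a saturated chain carbon, two bonds along the chain from an aromatic carbon. Among the measured compounds shown here, no measured step exchanges these two groups, so nothing bears on it directly. For the measured compounds named here, the one step on the same saturated chain carbon, from compound 1 to compound 2, changed the number only modestly, and a change of the chain end of comparable size, in either direction or none beyond the scatter, is the working expectation here. Compound 3 is accordingly expected to give about 100 nM in this assay , within 30 nM to 400 nM. Against compound 2 this estimate means an expected 1.3-fold lower number from compound 2 to compound 3 (0.12 log units; within the scatter), essentially within the scatter, pending the measurement.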

Compound 3, half-maximal inhibitory concentration: 11 nM
Compound 3: middle estimate off by 9.1-fold (0.96 log units), on the high side; measured number below the stated range.
By their numbers in this assay, from the lowest: compound 3; then compound 1; then compound 2.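

In this assay, within the data shown here, the chain end turns out to matter far more than the earlier pair could show: the only earlier step at this saturated chain carbon, two bonds along the chain from an aromatic carbon, was a 2.1-fold higher number from compound 1 to compound 2 (0.32 log units; beyond the scatter), whereas (hydroxyamino)methyl in place of carbamoyl there gives a 12-fold lower number from compound 2 to compound 3 (1.08 log units; beyond the scatter). This exchange keeps the heavy atoms the same in kind and number, yet the number still moves by a large step, so atom content alone does not set the value at this position, and the hydroxyamino end also improves on the nitrile end, with a 5.7-fold lower number from compound 1 to compound 3 (0.76 log units; beyond the scatter), leaving compound 3 with the lowest number of the three. No supporting measurement is available to account for this large step.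

The compounds shown leave open which part of the hydroxyamino end carries the effect, and a plain primary amine or a methoxyamino group on the same chain would separate the role of the terminal hydroxyl from that of the nitrogen. Also open, going by these compounds, is how far the result depends on chain length, which a shorter or longer chain ending in hydroxyamino would test.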